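The compounds below may be only part of what the source reports. "The series", "measured", "known", "first", "only" and "open" are said of these compounds alone.

Within the data shown here, compound 1 `CCCc1nc2c(C)cc(C(=O)N3CCCCC3)cc2n1Cc1ccc(-c2ccccc2C(=O)O)cc1` sits at the lower of the two numbers measured so far: in an assay on isolated protein for displacement of a labelled ligand from Type-2 angiotensin II receptor (Homo sapiens), with a stated time of 180 min (on this read-out lower numbers stand for stronger inhibition and higher numbers for weaker inhibition), compound 1 gives 42 nM. Its nearest neighbour is compound 2 `CCCC(=O)Nc1cc(C)c2nc(CCC)n(Cc3ccc(-c4ccccc4C(=O)O)cc3)c2c1`, which in this assay gives 53 nM; the change from one to the other was a 1.3-fold higher number from compound 1 to compound 2 (0.10 log units; within the scatter), so the two cannot be told apart.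

Compound 3 `CCCc1nc2c(C)cc(NC(=O)c3ccccc3)cc2n1Cc1ccc(-c2ccccc2C(=O)O)cc1` has not yet been measured. It differs from compound 1 in a single place: benzamido in place of (piperidin-1-yl)carbonyl on an aromatic carbon. Among the measured compounds shown here, the one measured step that bears on this, the one from compound 1 to compound 2, also exchanged the amide group at this same position of the shared core, and it left the number essentially unchanged. The new group in compound 3 is again an amide, now carrying a benzene ring rather than a propyl chain. On that basis the step from compound 1 to compound 3 is expected to be a 1.2-fold higher number from compound 1 to compound 3 (0.08 log units; within the scatter), with no movement beyond the scatter foreseen in either direction. Compound 3 is therefore estimated to give 50 nM in this assay, with a likely range from 20 nM to 130 nM.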

Compound 3, half-maximal inhibitory concentration: 6 nM
Beside the measured number, compound 3's estimate is 8.3-fold (0.92 log units) above it; measured number below the stated range.
By their numbers in this assay, from the lowest: compound 3; then compounds 1 and 2 (each within the scatter of the next).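

The position on the shared core turns out not to be indifferent to what it carries: in this assay the change to benzamido gives a 7.0-fold lower number from compound 1 to compound 3 (0.85 log units; beyond the scatter) and so goes beyond the scatter, which the earlier exchange of one amide for another did not. The more telling comparison is with compound 2, which also has the amide nitrogen on the aromatic carbon and differs only in the group on the carbonyl carbon: phenyl in place of propyl gives an 8.8-fold lower number from compound 2 to compound 3 (0.95 log units; beyond the scatter) and thus shows that this way of attaching the amide does not bring the lower number by itself, since the gain appears only once the phenyl is present. Nothing available here explains why the phenyl has this effect.

The compounds shown leave open whether the ring on the carbonyl carbon must be aromatic, which a cyclohexyl group in place of the phenyl would test. They also leave open how much the ring tolerates change, as a pyridine ring or a phenyl carrying a chlorine or a methoxy group could show.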